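The source may hold more compounds than are shown below. What is called first, only, known or untested is meant among the compounds shown, and "the series" means these compounds.

Measured in a functional assay on MIA PaCa-2 cells (Homo sapiens) for antiproliferative activity, read by sulforhodamine B assay, with a stated time of 48 h; on this read-out lower numbers stand for stronger inhibition and higher numbers for weaker inhibition:
- compound 1 `COc1ccc(C(=O)/C=C\Nc2ccc(-c3nc4cc(OC)c(OC)c(OC)c4s3)cc2C)cc1O`: 15400 nM
- compound 2 `COc1ccc(C(=O)/C=C\Nc2ccc(-c3nc4cc(OC)c(OC)c(OC)c4s3)cc2C)cc1[N+](=O)[O-]`: 23400 nM
- compound 3 `COc1ccc(C(=O)/C=C\Nc2ccc(-c3nc4cc(OC)c(OC)c(OC)c4s3)cc2)cc1[N+](=O)[O-]`: 15900 nM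

Compound 2 stands within the scatter of both other compounds, so the three form a single band. The next compound is compound 4 `COc1cc(C(=O)/C=C\Nc2ccc(-c3nc4cc(OC)c(OC)c(OC)c4s3)cc2C)cc(OC)c1OC`, with this change: 3,4,5-trimethoxyphenyl in place of 4-methoxy-3-nitrophenyl on a carbonyl carbon. The closest evidence is a 1.5-fold higher number from compound 1 to compound 2 (0.18 log units; within the scatter), which touches the 4-methoxy-3-nitrophenyl group itself. The other measured step, a 1.5-fold lower number from compound 2 to compound 3 (0.17 log units; within the scatter), does not touch that group. Both steps are small, and neither introduces the 3,4,5-trimethoxyphenyl group, so its effect remains unmeasured. No shift beyond the scatter is therefore expected in this assay. The expected step is a 1.7-fold lower number from compound 2 to compound 4 (0.22 log units; within the scatter). Compound 4 is estimated at 14000 nM, with an expected range of 5000 nM to 35000 nM.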

Compound 4, half-maximal inhibitory concentration: 22800 nM
Compound 4: middle estimate off by 1.6-fold (0.21 log units), on the low side, within the range that was stated.
By their numbers in this assay, from the lowest: compounds 1, 3, 4 and 2 (each within the scatter of the next).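

In this assay the 3,4,5-trimethoxyphenyl group on the carbonyl carbon is now measured: replacing 4-methoxy-3-nitrophenyl gives a 1.0-fold lower number from compound 2 to compound 4 (0.01 log units; within the scatter) and replacing 3-hydroxy-4-methoxyphenyl gives a 1.5-fold higher number from compound 1 to compound 4 (0.17 log units; within the scatter). With the rest of the structure kept, all three aryl groups at this position therefore fall in one band, and no change here has yet separated two compounds. No available measurement offers a cause for this.

On these data alone, whether a phenyl bearing an amine or a carboxylic acid in this place would stay in that band remains open. So does whether any group here gives a step beyond the scatter.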